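This account rests on a few compounds, and the source may have more. Where it says the series, first, only, none or still open, it means among the compounds named here.

Working notes on a sulfone-bearing series sharing one core. Compound 1 `O=S(=O)(c1ccccc1)c1cnc2ccccc2c1N1CCCCCC1` gives 310 nM in an assay on isolated protein for displacement of a labelled ligand from metabotropic glutamate receptor 5 (Homo sapiens), with a stated time of 60 min; on this read-out lower numbers stand for stronger inhibition and higher numbers for weaker inhibition. Compound 2 `CC1CCN(c2c(S(=O)(=O)c3cc(F)cc(F)c3)cnc3cc(Cl)ccc23)CC1` differs from compound 1 at several places on its core and on its sulfone aryl group; in this assay compound 2 gives 195 nM, and the two values lie within the scatter of each other. Compound 3 `O=S(=O)(c1ccccc1)c1cnc2ccccc2c1N1CCCC1` carries the pyrrolidin-1-yl group, but the entry for compound 3 in this assay reads "not determined" (no result reported), so it stands nowhere on the numbers shown. Compound 4 `O=S(=O)(c1ccccc1)c1cnc2ccccc2c1N1CCCCC1` differs from compound 3 in one place: piperidin-1-yl in place of pyrrolidin-1-yl on an aromatic carbon. Among the compounds with values here, with no measured pair of this kind, the step from compound 3 to compound 4 in this assay is given no direction; nothing beyond the scatter is assumed. Compound 4 is expected at 300 nM, with an estimated range of 100 nM to 900 nM. This expectation rests on the nearest measured analogue, compound 1, which gives 310 nM.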

Compound 4, inhibition constant: 307 nM
Compound 4: the middle estimate sits 1.0-fold (0.01 log units) below what was measured, and the stated range covers the measured number.
By their numbers in this assay, from the lowest: compounds 2, 4 and 1 (each within the scatter of the next).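

In this assay, within the data shown here, the only readable one-place pair gives (a 1.0-fold lower number from compound 1 to compound 4 (0.00 log units; within the scatter)), so at this position, opposite the ring nitrogen, azepan-1-yl and piperidin-1-yl cannot be told apart. The step from pyrrolidin-1-yl to piperidin-1-yl cannot be read: compound 3 has no number. No measurement shown offers a reason for the two rings reading alike.

Open, from the compounds shown here alone, is whether an open-chain amine such as dimethylamino, or morpholin-4-yl, would read the same at this position. Also open, going by these compounds, is whether the match holds with a substituted sulfone aryl group.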